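2-phenylethenyl for 1-methyl-1H-indol-2-yl on the hexyl-extended chain

This account rests on a few compounds, and the source may have more. Where it says the series, first, only, none or still open, it means among the compounds named here.

Compound 1 `CCCCCCCCCCCCNC(=O)[C@@H](NC(=O)c1cc2ccccc2n1C)[C@@H](C)O` and compound 3 `CCCCCCCCCCCCCCCCCCNC(=O)[C@@H](NC(=O)c1cc2ccccc2n1C)[C@@H](C)O` share a core; the two cores differ by hexyl in place of hydrogen on a saturated chain carbon, ten or more bonds along the chain from an amide-type nitrogen. In a functional assay on MCF7 cells (Homo sapiens) for cytotoxicity, read by MTT assay, with a stated time of 48 h (a lower number here means a stronger inhibitor, a higher number a weaker inhibitor), compound 1 gives 31300 nM, and compound 3 gives 36400 nM, the step being a 1.2-fold higher number from compound 1 to compound 3 (0.07 log units; within the scatter). Compound 2 `CCCCCCCCCCCCNC(=O)[C@@H](NC(=O)/C=C/c1ccccc1)[C@@H](C)O` carries the change (2-phenylethenyl in place of 1-methyl-1H-indol-2-yl on a carbonyl carbon). In this assay compound 2 reaches only a limit, > 200000 nM, as recorded by the limit of > 200000 nM in this assay, at which 1 of the 3 values shown sits. That step is an at least 6.3-fold higher number from compound 1 to compound 2 (0.80 log units; beyond the scatter). Compound 4 `CCCCCCCCCCCCCCCCCCNC(=O)[C@@H](NC(=O)/C=C/c1ccccc1)[C@@H](C)O` is not yet measured; it differs from compound 3 by 2-phenylethenyl in place of 1-methyl-1H-indol-2-yl on a carbonyl carbon, the same change at the same place, so the change appears in two pairs here. The step to compound 4 is expected to resemble the earlier one because an at least 6.3-fold higher number from compound 1 to compound 2 (0.80 log units; beyond the scatter) was seen on the shorter chain, which the hexyl extension barely altered. Compound 4 is therefore estimated at 250000 nM, between 120000 nM and 600000 nM, an expected step of a 6.9-fold higher number from compound 3 to compound 4 (0.84 log units; beyond the scatter).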

Compound 4, half-maximal inhibitory concentration: 39200 nM
Beside the measured number, compound 4's estimate is 6.4-fold (0.80 log units) above it, outside the stated range (below it).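

In this assay the change to 2-phenylethenyl does not carry over from one core to the other, and the step seen on the shorter chain is no guide to the hexyl-extended chain: the same change on two cores in this assay, an at least 6.3-fold higher number (0.80 log units; beyond the scatter) from compound 1 to compound 2 and a 1.1-fold higher number (0.03 log units; within the scatter) from compound 3 to compound 4, at least 5.9-fold (0.77 log units) apart, beyond the scatter of two such steps. On the hexyl-extended chain the change gives a 1.1-fold higher number from compound 3 to compound 4 (0.03 log units; within the scatter), whereas the addition of hexyl gives an at least 5.1-fold lower number from compound 2 to compound 4 (0.70 log units; beyond the scatter), so the effects of the two changes do not simply add: the same change on two cores in this assay, a 1.2-fold higher number (0.07 log units; within the scatter) from compound 1 to compound 3 and an at least 5.1-fold lower number (0.70 log units; beyond the scatter) from compound 2 to compound 4, at least 5.9-fold (0.77 log units) apart, beyond the scatter of two such steps. Compound 2 gives > 200000 nM, which is a limit of the assay, and these four compounds do not show why the two steps differ.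

On these data alone, it remains open whether a longer chain would keep the two carbonyl substituents level. Also open, as far as these compounds go, is how an amine on the chain would behave in this assay.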